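The source may hold more compounds than are shown below. What is called first, only, known or untested is meant among the compounds shown, and "the series" means these compounds.

Four compounds share one core and differ in the groups hung from it. Compound 1 `Cc1nc(C(=O)O)c(N)c2c1C(=O)N(Cc1ccccc1)C2=O` carries a carboxylic acid; compound 2 `CNC(=O)c1nc(C)c2c(c1N)C(=O)N(Cc1ccccc1)C2=O` carries a methylamide in its place; compound 3 `Cc1noc(-c2nc(C)c3c(c2N)C(=O)N(Cc2ccc(Br)cc2)C3=O)n1` and compound 4 `Cc1noc(-c2nc(C)c3c(c2N)C(=O)N(Cc2ccc(C#N)cc2)C3=O)n1` carry a methyl-oxadiazole and a substituted benzyl group. In a physicochemical assay for solubility, using the shake flask method, in simulated intestinal fluid, measured as kinetic solubility, with a stated time of 2 h, at 25 degrees C, at pH 6.5 (on this read-out higher numbers stand for higher solubility and lower numbers for lower solubility), compound 1 gives 177000 nM. In this assay, for the measured compounds named here, compound 2 gives 41000 nM, so the single measured step, a 4.3-fold lower number from compound 1 to compound 2 (0.64 log units; beyond the scatter), is a modest drop for methylamino in place of hydroxy on a carbonyl carbon.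

Compound 3 stands apart from both. In this assay compound 3 gives only a limit, < 5000 nM, not a number. On these data alone, this is the limit of < 5000 nM in this assay, at which 1 of the 3 values shown sits, so where compound 3 truly sits under that limit is unknown.

The change to compound 4 is cyano in place of bromo on an aromatic carbon. No measured step covers a swap of this kind: the one step shown concerns the acid-to-amide change between compound 1 and compound 2 and says nothing about a substituent on the benzyl ring. With compound 3 already at the limit, the expected step that the limit leaves unreadable from compound 3 to compound 4 is small and within the scatter. Compound 4 is therefore estimated to give 4000 nM, with a range from 800 nM to 20000 nM, and it may well again return only a limit.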

Compound 4, solubility: < 5000 nM
Compound 4: only a limit was reported; the forecaster's own chance of this, stated with the estimate: 55%; the middle value does not contradict the limit.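

In this assay compound 4 gives only a limit, < 5000 nM, not a number. Compound 3 gives a limit too, so no step from compound 3 to compound 4 can be read: the limit of < 5000 nM in this assay, at which 2 of the 4 values shown sit.

The compounds shown leave open where compound 3 and compound 4 truly sit under that limit, and whether cyano in place of bromo changes the read-out at all.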